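This account rests on a few compounds, and the source may have more. Where it says the series, first, only, none or still open, it means among the compounds named here.

Of the compounds shown here, three built on a shared core have been measured in an assay for inhibition of Amine oxidase [flavin-containing] B (Rattus norvegicus); a lower number here means a stronger inhibitor, a higher number a weaker inhibitor. Compound 1, `NC(=O)[C@H](CO)Nc1cc(=O)oc2cc(OCc3cccc(Cl)c3)ccc12`, gives 2400 nM. Compound 2, `NNC(=O)Cc1cc(=O)oc2cc(OCc3cccc(Cl)c3)ccc12`, gives 90 nM. Compound 3, `NC(=O)Cc1cc(=O)oc2cc(OCc3cccc(Cl)c3)ccc12`, gives 30 nM. Compound 3 therefore stands as the strongest inhibitor of the three: the steps of an 80-fold lower number from compound 1 to compound 3 (1.90 log units; beyond the scatter) and a 3.0-fold lower number from compound 2 to compound 3 (0.48 log units; beyond the scatter) are both beyond the scatter, and the step of a 27-fold lower number from compound 1 to compound 2 (1.43 log units; beyond the scatter) shows that most of the gain came from exchanging the (1-carbamoyl-2-hydroxyethyl)amino group for a simpler two-carbon amide arm.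

Compound 4, `NC(=O)Cc1cc(=O)oc2cc(OCc3cccc(O)c3)ccc12`, differs from compound 3 in one place: hydroxy in place of chloro on an aromatic carbon. None of the three measured steps touches this part of the molecule; all of them alter the arm on the other side of the core, while the chlorinated benzyl ether was kept the same in every measured compound. For the measured compounds named here, there is thus no measured precedent within this set for what exchanging chloro for hydroxy on that ring does. The expectation for compound 4 is accordingly uncertain, with a step of a 10-fold higher number from compound 3 to compound 4 (1.00 log units; beyond the scatter) expected, leaning toward a weaker inhibitor. Compound 4 is estimated at 300 nM, with a range from 50 nM to 2000 nM.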

Compound 4, half-maximal inhibitory concentration: 1000 nM
For compound 4 the middle estimate is 3.3-fold (0.52 log units) below the measured one; low and high end bracket the measured number.
By their numbers in this assay, from the lowest: compound 3; then compound 2; then compound 4; then compound 1.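

In this assay, the arm on the other side of the core is not the only part that matters, since changing the ring of the benzyl ether also moves the number strongly: a 33-fold higher number from compound 3 to compound 4 (1.52 log units; beyond the scatter). One heavy atom replaces one heavy atom here, with a hydrogen-bond donor and a hydrogen-bond acceptor entering, yet this step is larger than the step from removing the amino group of the arm, a 3.0-fold lower number from compound 2 to compound 3 (0.48 log units; beyond the scatter), so a small edit at this place on the ring can count for much. Nothing available explains why hydroxy in place of chloro gives a weaker inhibitor here.

The compounds shown do not separate losing chloro from gaining hydroxy, and a 3-methoxybenzyl, 3-fluorobenzyl or plain benzyl group at this place would help tell those two apart. Going by these compounds, it also remains open whether the same exchange would have a similar size on the other arms, such as the (aminocarbamoyl)methyl arm of compound 2 or the (1-carbamoyl-2-hydroxyethyl)amino group of compound 1.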